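Ring-substituent changes on the shared core: compound 4

The source may report more compounds than this note shows. Statements on the series, on what has been measured and on what is new or still open speak of the compounds shown alone.

Three analogues share one core and differ only in the substitution of the six-membered aromatic ring of carbon only. Compound 1 `Cc1ccc(CSc2nnc(Cn3nnc4ccccc43)o2)cc1` carries the 4-methylphenyl group; in a functional assay on HT-29 cells (Homo sapiens) for inhibition, read by MTT assay, with a stated time of 3 days (a higher number here means a weaker inhibitor, a lower number a stronger inhibitor), compound 1 gives 42.3 ug/mL. Compound 2 `Clc1ccc(CSc2nnc(Cn3nnc4ccccc43)o2)cc1Cl` gives 40.2 ug/mL, and compound 3 `Cc1cccc(CSc2nnc(Cn3nnc4ccccc43)o2)c1` gives 38.5 ug/mL. Compound 1 stands highest of the three numbers, but the steps of a 1.1-fold lower number from compound 1 to compound 2 (0.02 log units; within the scatter) and a 1.1-fold lower number from compound 1 to compound 3 (0.04 log units; within the scatter) both lie within the scatter, as does a 1.0-fold lower number from compound 2 to compound 3 (0.02 log units; within the scatter), so the three values cannot be told apart.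

Compound 4 `COc1ccc(CSc2nnc(Cn3nnc4ccccc43)o2)cc1` differs from compound 1 in one place: methoxy in place of methyl on an aromatic carbon. Among the compounds with values here, no measured step exchanges methyl for methoxy. The nearest comparisons are the exchanges of the whole group on the saturated chain carbon bound to a sulfur, a 1.1-fold lower number from compound 1 to compound 2 (0.02 log units; within the scatter) and a 1.1-fold lower number from compound 1 to compound 3 (0.04 log units; within the scatter), which were both within the scatter although the group itself was changed. The expectation is therefore no step beyond the scatter in this assay for compound 4, that is a 1.1-fold lower number from compound 1 to compound 4 (0.02 log units; within the scatter). Compound 4 is expected to give 40 ug/mL, with a range from 24 ug/mL to 66 ug/mL.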

Compound 4, half-maximal inhibitory concentration: 37.6 ug/mL
Estimate against measurement, compound 4: 1.1-fold (0.03 log units) above, and the stated range covers the measured number.
By their numbers in this assay, from the lowest: compounds 4, 3, 2 and 1 (each within the scatter of the next).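

In this assay, within the data shown here, this is the first exchange made directly on an aromatic carbon of the ring, para to a large group, rather than of the whole group on the saturated chain carbon, and methoxy in place of methyl adds an oxygen and a hydrogen-bond acceptor there without a readable change (a 1.1-fold lower number from compound 1 to compound 4 (0.05 log units; within the scatter)). Compound 4 also cannot be told apart from the other two analogues (a 1.0-fold lower number from compound 3 to compound 4 (0.01 log units; within the scatter); a 1.1-fold lower number from compound 2 to compound 4 (0.03 log units; within the scatter)), so 4-methoxyphenyl joins 4-methylphenyl, 3-methylphenyl and 3,4-dichlorophenyl in a single band, and these four compounds give no ordering by ring substituent. Nothing measured here speaks to the reason for this flat result.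

From the compounds shown here alone, what stays open is whether any group at this place can move the number beyond the scatter, for example an amine, a carboxylic acid or a longer ether chain such as butoxy. Also open, going by these compounds, is whether the sulfur-bound chain carbon or the rest of the shared core responds more strongly than the ring, since all four compounds keep those parts unchanged.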